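Chloro for hydrogen on the aryl amide, two cores

This account rests on a few compounds, and the source may have more. Where it says the series, first, only, none or still open, it means among the compounds named here.

Compound 1 `O=C(CCCCC(S)CCS)Nc1ccccc1` gives 1.32% in a functional assay on Bel-7402 cells (Homo sapiens) for inhibition, read by MTT assay, with a stated time of 24 h, tested at 1 ug/mL; a higher number here means more inhibition of growth at the concentration tested, a lower number less inhibition of growth. Compound 2 `O=C(CCCCC(S)CCS)Nc1ccccc1Cl` carries chloro in place of hydrogen on an aromatic carbon and gives 3.08% in this assay, a step of a number 1.8 percentage points higher from compound 1 to compound 2 (within the scatter). Compound 3 `O=C(CCCCC(S)CCS)Nc1ccccn1` differs from compound 1 in its core by pyridin-2-yl in place of phenyl on an amide-type nitrogen; in this assay compound 3 is reported as "not active" (no number reported), so no number stands for it. Compound 4 `O=C(CCCCC(S)CCS)Nc1ccc(Cl)cn1` is not yet measured and carries chloro in place of hydrogen on an aromatic carbon. This is the same kind of change as in compound 2, not the same: there the place is on a six-membered aromatic ring of carbon only, ortho to a large group, here on a six-membered aromatic ring with 1 nitrogen, two atoms from the ring nitrogen, para to a large group. A step of similar small size is expected in this assay, resting on the earlier step of a number 1.8 percentage points higher from compound 1 to compound 2 (within the scatter) and on the low values of compound 1 and compound 2. With no number for compound 3, a return of only a limit cannot be ruled out. Compound 4 is expected to give about 3%, estimated within -5% to 12%.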

Compound 4, percent growth inhibition at one concentration: 2.34%
For compound 4 the middle estimate is 0.7 percentage points above the measured one, and the stated range covers the measured number.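

For the compounds shown here, compound 3 has no number in this assay and no step from it to compound 4 can be read. The compounds shown leave open whether chloro in place of hydrogen on the ring with nitrogen changes growth inhibition at all, or whether higher concentrations separate them. No measured evidence bears on this result.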